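A few compounds are considered here, and "the series" means these few. Any claim that something is new, unique, unknown or untested is made for them only; others in the source may bear on it.

Compound 2 `CCN1CCN(c2c(S(=O)(=O)c3ccccc3)cnc3ccccc23)CC1` was tested in an assay on isolated protein for displacement of a labelled ligand from metabotropic glutamate receptor 5 (Homo sapiens), with a stated time of 60 min (a lower number here means a stronger inhibitor, a higher number a weaker inhibitor), but for compound 2 the outcome is recorded only as "not determined" (no result reported), so no number for it exists. The only measured reference in this series is compound 1 `O=S(=O)(c1cccc(Cl)c1)c1cnc2cc(Cl)ccc2c1N1CCC(CO)CC1`, which in this assay gives 30.9 nM. Compound 3 `O=S(=O)(c1ccccc1)c1cnc2ccccc2c1N1CCCCC1` has not yet been measured. It differs from compound 2 in one place: piperidin-1-yl in place of 4-ethylpiperazin-1-yl on an aromatic carbon. Within the data shown here, since compound 2 has no value, no step between compound 2 and compound 3 can be computed, and the expected size of the step in this assay cannot be stated as a number; it may be none beyond the scatter, or it may be larger, in either direction. Compound 3 shares the core of compound 1 but carries fewer groups on it, and compound 1 gives 30.9 nM, so compound 3 is expected to come out at around 200 nM, within a range from 30 nM to 1500 nM.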

Compound 3, inhibition constant: 307 nM
Compound 3: middle estimate off by 1.5-fold (0.19 log units), on the low side; low and high end bracket the measured number.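

Among these compounds, compound 2 has no number to compare, and no step from it to compound 3 can be read. The compounds shown leave open how exchanging 4-ethylpiperazin-1-yl for piperidin-1-yl changes binding in this assay, and no evidence bears on the result.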